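A few compounds are considered here, and "the series" means these few. Any claim that something is new, unique, unknown or untested is made for them only; others in the source may bear on it.

In an ADME assay on microsomes from liver (Rattus norvegicus) for metabolic stability (a higher number here means faster removal of the compound, a lower number slower removal), compound 1 `N#Cc1ccccc1COc1ccc([C@H]2CC[C@@H](C(N)=O)N2)cc1` gives 1.4 mL.min-1.g-1 and compound 2 `NC(=O)[C@@H]1CC[C@H](c2ccc(OCc3ccc(F)cc3)cc2)N1` gives 1.8 mL.min-1.g-1, two values within the usual scatter of each other, while compound 3 `COc1cc([C@H]2CC[C@@H](C(N)=O)N2)ccc1OCc1ccccc1F` gives 4 mL.min-1.g-1, a clearly higher number. Compound 2 therefore sits with compound 1 at the low end of this small set. The unmeasured compound 4 `N#Cc1ccc(COc2ccc([C@H]3CC[C@@H](C(N)=O)N3)cc2)cc1` differs from compound 2 in one place: cyano in place of fluoro on an aromatic carbon. This puts cyano in place of fluoro on an aromatic carbon, para to a large group, turning 4-fluorophenyl into 4-cyanophenyl. No measurement shows this exact swap. The nearest evidence is a 1.3-fold higher number from compound 1 to compound 2 (0.11 log units; within the scatter), where 4-fluorophenyl took the place of 2-cyanophenyl. That step stayed within the scatter, though a single pair is thin evidence. In this assay no step beyond the scatter is therefore expected, and the estimated move is a 1.1-fold lower number from compound 2 to compound 4 (0.05 log units; within the scatter). For compound 4 the expected value is 1.6 mL.min-1.g-1, with an estimated range of 0.8 mL.min-1.g-1 to 3.2 mL.min-1.g-1.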

Compound 4, intrinsic clearance in microsomes: 0.6 mL.min-1.g-1
Beside the measured number, compound 4's estimate is 2.7-fold (0.43 log units) above it; the whole stated range lies above it.
By their numbers in this assay, from the lowest: compound 4; then compounds 1 and 2 (each within the scatter of the next); then compound 3.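

In this assay, going by these compounds alone, cyano in place of fluoro on an aromatic carbon, para to a large group, gives a 3.0-fold lower number from compound 2 to compound 4 (0.48 log units; beyond the scatter) and so, unlike the one earlier step, this change moves the number beyond the scatter. The place of the nitrile on the ring also counts here, since 4-cyanophenyl in place of 2-cyanophenyl gives a 2.3-fold lower number from compound 1 to compound 4 (0.37 log units; beyond the scatter) even though both compounds carry the same group. Nothing measured here accounts for either step.

From the compounds shown here alone, each step rests on a single pair of compounds, so it remains open whether the same change would act alike on a core carrying a further group. Going by these compounds, it also remains open how other groups in this place, such as an amine or a carboxylic acid, would compare with cyano and fluoro.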